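The compounds below may be only part of what the source reports. "The series", "measured", "known", "first", "only" and "open" are said of these compounds alone.

Compound 1 `COc1ccc(SC)c(NCC2=NCCN2)c1` gives 3.63 nM in a functional assay for agonist activity at Alpha-1B adrenergic receptor (Homo sapiens); a higher number here means that more compound is needed for the effect, a lower number that less compound is needed. Compound 2 `CSc1ccc(Cl)cc1NCC1=NCCN1` gives 0.501 nM in this assay, the lowest of the two numbers, and the step of a 7.2-fold lower number from compound 1 to compound 2 (0.86 log units; beyond the scatter) is the only one measured so far. Compound 3 `CSc1ccc(C(F)(F)F)cc1NCC1=NCCN1` carries trifluoromethyl in place of chloro on an aromatic carbon. Among the compounds with values here, no measured step puts trifluoromethyl in that place, so the only guide is that compound 2, with chloro, already stands at the low end; a step of about a 1.6-fold higher number from compound 2 to compound 3 (0.20 log units; within the scatter) is expected, not clearly beyond the scatter. Compound 3 is thus estimated at 0.8 nM in this assay, with a range from 0.3 nM to 2.5 nM.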

Compound 3, half-maximal effective concentration: 6.03 nM
The estimate for compound 3 lay 7.5-fold (0.88 log units) below the measured number, and the stated range ends below it.
By their numbers in this assay, from the lowest: compound 2; then compounds 1 and 3 (each within the scatter of the next).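

At this place, para to a methylsulfanyl group, the step of a 12-fold higher number from compound 2 to compound 3 (1.08 log units; beyond the scatter) in this assay shows that the low number of compound 2 does not carry over from chloro to trifluoromethyl. The step of a 1.7-fold higher number from compound 1 to compound 3 (0.22 log units; within the scatter) leaves methoxy and trifluoromethyl unseparated, so among these three groups only chloro stands apart. Nothing available here bears on the origin of this difference.

Open, going by these compounds, is whether fluoro, bromo or methyl in this place would group with chloro or with methoxy and trifluoromethyl. Also open, on these data alone, is whether chloro keeps its standing when the methylsulfanyl group gives way to methoxy.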